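Compound 1 Without Its Methoxy Group

The source may report more compounds than this note shows. Statements on the series, on what has been measured and on what is new or still open speak of the compounds shown alone.

Of the compounds shown here, two have been measured in a functional assay on CCRF-CEM cells (Homo sapiens) for cytotoxicity; on this read-out lower numbers stand for stronger inhibition and higher numbers for weaker inhibition. Compound 1 (`COc1ccc(NC(=O)/C=C/C(=O)N2C/C(=C\c3ccc([N+](=O)[O-])cc3)C(=O)/C(=C/c3ccc([N+](=O)[O-])cc3)C2)cc1`) gives 760 nM, the lower of the two numbers, and compound 2 (`O=C(/C=C/C(=O)N1C/C(=C\c2ccccc2)C(=O)/C(=C/c2ccccc2)C1)Nc1ccc([N+](=O)[O-])cc1`) gives 40000 nM, a gap well beyond the usual scatter. These two compounds differ in more than one place, so the gap cannot be pinned on any single group.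

The next compound, compound 3 (`O=C(/C=C/C(=O)N1C/C(=C\c2ccc([N+](=O)[O-])cc2)C(=O)/C(=C/c2ccc([N+](=O)[O-])cc2)C1)Nc1ccccc1`), keeps the core of compound 1 and changes one thing: hydrogen in place of methoxy on an aromatic carbon. Among the measured compounds shown here, no measured pair shows what this swap does on its own, so any expectation here has little direct support. Measured against compound 2, compound 3 stands structurally closer to compound 1 at 760 nM, so only a modest rise in the number is expected in this assay, perhaps none beyond the scatter. The expected change is a 1.3-fold higher number from compound 1 to compound 3 (0.12 log units; within the scatter), a small move toward weaker inhibition. For compound 3 the estimated value is 1000 nM, with an expected range from 280 nM to 4500 nM.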

Compound 3, half-maximal inhibitory concentration: 370 nM
For compound 3 the middle estimate is 2.7-fold (0.43 log units) above the measured one, and the stated range covers the measured number.
By their numbers in this assay, from the lowest: compound 3; then compound 1; then compound 2.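

Among the compounds shown here, this is the first pair that differs in one place only, so the effect of one change can finally be read on its own. In this assay, putting hydrogen in place of methoxy on the anilide ring gives a 2.1-fold lower number from compound 1 to compound 3 (0.31 log units; beyond the scatter), a modest step toward stronger inhibition that only just clears the usual scatter. The methoxy group, on an aromatic carbon para to a large group, is therefore not needed for the cytotoxicity seen with the core of compound 1, and the simpler phenyl ring does slightly better on this read-out. No measurement on hand offers an explanation for this shift.

This single pair gives one swap at one position on one core, so it cannot show whether any other group at that carbon would push the number lower or higher, such as a fluorine atom, a hydroxyl group or an amine. It also leaves open whether the same swap would move the number in the same direction on a different core, such as the one carrying unsubstituted benzylidene rings in compound 2.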